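This account rests on a few compounds, and the source may have more. Where it says the series, first, only, none or still open, it means among the compounds named here.

The measured compounds:

- compound 1 `Oc1cccc(NCCCN2CCN(c3ccccc3)CC2)c1`: 10.1 nM
- compound 2 `CC(=O)Nc1cccc(N(C)CCCN2CCN(c3ccccc3)CC2)c1`: 161 nM
- compound 3 `CN(CCCN1CCN(c2ccccc2)CC1)c1cccc(NS(C)(=O)=O)c1`: 39.6 nM

All three were tested in an assay on HEK293 cells for displacement of a labelled ligand from 5-hydroxytryptamine receptor 7 (Homo sapiens), read by scintillation counting, with a stated time of 30 min; on this read-out higher numbers stand for weaker inhibition and lower numbers for stronger inhibition. Compound 1 gives the lowest number of the three; the nearest is compound 3 and the furthest compound 2, and both gaps lie beyond the scatter, so compound 1 is the strongest binder shown. Among the compounds with values here, the only single-point step among the measured compounds is a 4.1-fold lower number from compound 2 to compound 3 (0.61 log units; beyond the scatter). That step swaps one group for another on a nitrogen attached to the ring, and it says nothing direct about altering the group on the ring carbon that distinguishes compound 4.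

Compound 4 `OCc1cccc(NCCCN2CCN(c3ccccc3)CC2)c1` differs from compound 1 in one place: hydroxymethyl in place of hydroxy on an aromatic carbon. Within the data shown here, no measured pair tests this exchange, so the expectation rests on the change being small in size and keeping one donor and one acceptor on the ring. The expected outcome is a step of a 2.0-fold higher number from compound 1 to compound 4 (0.30 log units; within the scatter), which would stay close to the scatter of this assay, with a slight lean towards a higher number because the hydroxy of compound 1 carries the lowest value, 10.1 nM, and any alteration is more likely to lose than gain. Compound 4 is therefore estimated at 20 nM, within a range from 6 nM to 70 nM.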

Compound 4, inhibition constant: 109 nM
Compound 4: the middle estimate sits 5.5-fold (0.74 log units) below what was measured; measured number above the stated range.
By their numbers in this assay, from the lowest: compound 1; then compound 3; then compounds 4 and 2 (each within the scatter of the next).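

The 2 heavy atoms of hydroxymethyl replace the 1 of hydroxy with the same count of hydrogen-bond donors and acceptors, yet in this assay the exchange gives an 11-fold higher number from compound 1 to compound 4 (1.03 log units; beyond the scatter). Matching those counts is therefore not enough to hold the binding here, and a change that looks minor on paper can be a large one at this aromatic carbon. This is also the first direct reading at this ring carbon, as the earlier step concerned a group on a nitrogen attached to the ring, and no measurement shown accounts for the size of the new step.

A single pair cannot tell whether other groups on this aromatic carbon, such as a methoxy, an amine or a longer chain like 2-hydroxyethyl, would give numbers closer to that of compound 1 or to that of compound 4. As far as these compounds go, it also remains open whether the same exchange would have a similar effect on a core carrying the methyl-substituted nitrogen found in compound 2 and compound 3.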